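This account rests on a few compounds, and the source may have more. Where it says the series, first, only, none or still open, it means among the compounds named here.

Working notes on the series. In an ADME assay on MT4 cells (Homo sapiens) for cytotoxicity, read by MTT assay (a lower number here means that less compound is tolerated, a higher number that more compound is tolerated), compound 1 (`Cc1ccc(NC(=O)CSc2nncnc2-c2cccc3ccccc23)c(Br)c1`) gives 166000 nM, compound 2 (`Cc1ccccc1NC(=O)CSc1nncnc1-c1ccccc1Cl`) gives 142000 nM and compound 3 (`O=C(CSc1nncnc1-c1ccccc1Cl)Nc1cccnc1Cl`) gives 167000 nM. These three values lie within the scatter of each other, so compound 1 holds no separate rank among them.

Compound 4 (`Cc1ccc(NC(=O)CSc2nncnc2-c2cccc3ccccc23)c([N+](=O)[O-])c1`) is still unmeasured and departs from compound 1 by one exchange: nitro in place of bromo on an aromatic carbon. This places nitro in place of bromo on an aromatic carbon, ortho to a large group.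

For the measured compounds named here, the only measured single-place step is a 1.2-fold higher number from compound 2 to compound 3 (0.07 log units; within the scatter). It is a different exchange and offers indirect guidance only. Going by the values given here, no measured pair swaps bromo for nitro, so the size of this step cannot be read directly from the data. With that one step inside the scatter, no shift beyond the scatter is expected in this assay, and no firm direction can be assigned.

The estimated change is a 1.2-fold lower number from compound 1 to compound 4 (0.07 log units; within the scatter). For compound 4 the estimated value is 140000 nM, with an expected range of 70000 nM to 230000 nM.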

Compound 4, half-maximal cytotoxic concentration: 147000 nM
Compound 4: the middle estimate sits 1.1-fold (0.02 log units) below what was measured; the range from low to high includes it.
By their numbers in this assay, from the lowest: compounds 2, 4, 1 and 3 (each within the scatter of the next).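

For the compounds shown here, at this position, ortho to a large group, the exchange of bromo for nitro on an aromatic carbon gives in this assay a 1.1-fold lower number from compound 1 to compound 4 (0.05 log units; within the scatter) and so supplies the one measured step at this place. The earlier compounds shown here held no pair that differed here, and this pair shows that going from 2-bromo-4-methylphenyl to 4-methyl-2-nitrophenyl, with 1 heavy atom leaving and 3 heavy atoms entering, keeps the number within the scatter on the core of compound 1. Nothing at hand offers an explanation for this result.

Going by these compounds, whether an amine or a carboxylic acid at this same position would also stay within the scatter remains open. So does whether nitro in place of bromo reads the same on a different core.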